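Trimming methyls from a pyrimidine sulfonamide

The compounds below may be only part of what the source reports. "The series", "measured", "known", "first", "only" and "open" are said of these compounds alone.

Of the compounds shown here, three sharing one core have been tested in a functional assay on MCF7 cells (Homo sapiens) for cytotoxicity, read by sulforhodamine B assay, with a stated time of 72 h; on this read-out higher numbers stand for weaker inhibition and lower numbers for stronger inhibition. Compound 2 `O=C1/C(=C/c2coc3ccccc3c2=O)N=C(c2ccccc2)N1c1ccc(S(=O)(=O)Nc2nccs2)cc1` gives 88500 nM. Compound 3 `Cc1cc(C)nc(NS(=O)(=O)c2ccc(N3C(=O)/C(=C/c4coc5ccccc5c4=O)N=C3c3ccccc3)cc2)n1` gives 99700 nM, the higher of the two numbers, although the step of a 1.1-fold higher number from compound 2 to compound 3 (0.05 log units; within the scatter) lies within the scatter, so the two cannot be ordered. Compound 1 `O=C1/C(=C/c2coc3ccccc3c2=O)N=C(c2ccc(Cl)cc2)N1c1ccc(S(=O)(=O)Nc2ncccn2)cc1` gives > 100000 nM; this is a limit of the assay rather than a number, namely (the limit of > 100000 nM in this assay, at which 1 of the 3 values shown sits).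

Compound 4 `O=C1/C(=C/c2coc3ccccc3c2=O)N=C(c2ccccc2)N1c1ccc(S(=O)(=O)Nc2ncccn2)cc1` is compound 3 with pyrimidin-2-yl in place of 4,6-dimethylpyrimidin-2-yl on a sulfonamide nitrogen. Among the compounds with values here, no measured step covers exactly this pair. Within the data shown here, the only measured change on the sulfonamide nitrogen, a 1.1-fold higher number from compound 2 to compound 3 (0.05 log units; within the scatter), stayed within the scatter, suggesting that the group on this nitrogen matters little here. Compound 1 also carries a pyrimidin-2-yl group on that nitrogen and sits at the limit, while compound 4 lacks its chlorine; without a computed step between them, this only shows that a pyrimidin-2-yl sulfonamide can reach the top of this range.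

Compound 4 is therefore expected to give about 100000 nM, between 50000 nM and 200000 nM. The estimated step of a 1.0-fold higher number from compound 3 to compound 4 (0.00 log units; within the scatter) is expected to stay within the scatter.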

Compound 4, half-maximal inhibitory concentration: > 100000 nM
Compound 4 was reported as a limit; the forecaster's own chance of this, stated with the estimate: 40%; the middle value lies on the limit itself.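

Compound 4 ends at a limit of the assay and not at a number, so pyrimidin-2-yl in place of 4,6-dimethylpyrimidin-2-yl on the sulfonamide nitrogen gives a number no lower from compound 3 to compound 4 (the limit leaves the size open) in this assay, with no sign of stronger inhibition. Set against 1,3-thiazol-2-yl, pyrimidin-2-yl gives an at least 1.1-fold higher number from compound 2 to compound 4 (0.05 log units; that floor lies within the scatter), so only a floor is known and the true gap stays open. The steps to compound 4 from compound 3 and from compound 1 cannot be read, because the values involved sit at the limit: the limit of > 100000 nM in this assay, at which 2 of the 4 values shown sit.

From the compounds shown here alone, it remains open whether any change can bring these compounds down to clearly lower numbers. A hydrogen on the sulfonamide nitrogen, or an amine or a carboxylic acid on the aromatic carbon that carries chloro in compound 1, would test this.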